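The compounds below may be only part of what the source reports. "The series", "measured", "known", "first", "only" and "open" are said of these compounds alone.

Measured so far:
- compound 1, `Cn1cc(-c2nc3c(-c4ccc(CNC(=O)c5nc(C(C)(C)C)no5)c(F)c4)ccnc3[nH]2)cn1`: 11 10^-6 cm/s
- compound 2, `Cn1cc(-c2nc3c(-c4ccc(CNC(=O)c5nc(C6(C)CC6)no5)c(F)c4)ccnc3[nH]2)cn1`: 2.8 10^-6 cm/s
- compound 3, `Cn1cc(-c2nc3c(-c4ccc(CNC(=O)c5cc6c(s5)CCCC6)c(F)c4)ccnc3[nH]2)cn1`: 0.6 10^-6 cm/s

These three compounds share one core and differ only in the group attached to the amide carbonyl. They were tested in an ADME assay on Caco-2 cells (Homo sapiens) for permeability, in the apical to basolateral direction (on this read-out higher numbers stand for higher permeability and lower numbers for lower permeability), and compound 1 gives the highest number of the three. Swapping its tert-butyl for a 1-methylcyclopropyl gives a 3.9-fold lower number from compound 1 to compound 2 (0.59 log units; beyond the scatter), while replacing the whole five-membered aromatic ring that carries the tert-butyl with a sulfur-containing bicyclic group gives an 18-fold lower number from compound 1 to compound 3 (1.26 log units; beyond the scatter); the same bicyclic group measured against compound 2 gives a 4.7-fold lower number from compound 2 to compound 3 (0.67 log units; beyond the scatter).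

Compound 4, `Cn1cc(-c2nc3c(-c4ccc(CNC(=O)c5ccc(C(C)(C)C)cn5)c(F)c4)ccnc3[nH]2)cn1`, is built from compound 1 by the change (a group of 10 heavy atoms (9 carbon, 1 nitrogen; one six-membered aromatic ring with 1 hetero atom) in place of a group of 9 heavy atoms (6 carbon, 2 nitrogen, 1 oxygen; one five-membered aromatic ring with 3 hetero atoms), on a carbonyl carbon). Both measured steps that exchanged the ring on the carbonyl carbon moved downward, one of them strongly, whereas the step that only altered a substituent on that ring moved downward modestly. The change to compound 4 is also a ring exchange, although the entering group keeps the tert-butyl and stays aromatic, so a smaller loss than in compound 3 seems more likely. Compound 4 is therefore expected to show a 2.2-fold lower number from compound 1 to compound 4 (0.34 log units; beyond the scatter), an estimated 5 10^-6 cm/s with a range from 2 10^-6 cm/s to 12 10^-6 cm/s.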

Compound 4, apparent permeability: 0.3 10^-6 cm/s
The estimate for compound 4 lay 17-fold (1.22 log units) above the measured number; measured number outside the range, below it.
By their numbers in this assay, from the lowest: compounds 4 and 3 (each within the scatter of the next); then compound 2; then compound 1.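

In this assay, keeping the tert-butyl is not enough to hold the number: placing 5-(tert-butyl)pyridin-2-yl on the carbonyl carbon gives a 37-fold lower number from compound 1 to compound 4 (1.56 log units; beyond the scatter), a larger step than the substituent swap in compound 2 produced, so the ring carrying that group counts at this position as well as the group itself. The same entering group gives a 9.3-fold lower number from compound 2 to compound 4 (0.97 log units; beyond the scatter), whereas its comparison with the sulfur-containing bicyclic group gives a 2.0-fold lower number from compound 3 to compound 4 (0.30 log units; within the scatter), so compound 3 and compound 4 cannot be told apart here even though their ring groups look quite different. No measurement shown here explains why this ring exchange has such a large effect.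

The pyridine ring differs from the five-membered aromatic ring with 3 hetero atoms in both ring size and hetero atoms, so these compounds cannot separate the two changes. Going by these compounds, an isoxazole or a pyrimidine carrying the same tert-butyl on the carbonyl carbon would help to divide them, and where such rings would fall on this read-out remains open.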